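The source may hold more compounds than are shown below. What is called first, only, known or untested is meant among the compounds shown, and "the series" means these compounds.

Measured so far in a physicochemical assay for metabolic stability, read by HPLC, in phosphate buffer, at pH 7.4, tested at 10 uM; on this read-out lower numbers stand for a shorter-lived compound and higher numbers for a longer-lived compound:

compound 1 `O=C(NCCCCc1ccccc1)n1c(=O)oc2ccc(-c3ccccc3)cc21` — compound 1 gives 4.93 h
compound 2 `COc1ccc(-c2ccc3oc(=O)n(C(=O)NCCCCc4ccccc4)c3c2)cc1` — compound 2 gives 2.93 h

Among the compounds with values here, compound 2 holds the lowest of the two numbers in this assay; its nearest neighbour is compound 1, and the only step between them, a 1.7-fold lower number from compound 1 to compound 2 (0.23 log units; within the scatter), lies within the scatter. On the numbers in hand, then, the two compounds cannot be told apart.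

Compound 3 `O=C(NCCCCc1ccccc1)n1c(=O)oc2ccc(-c3ccc(F)cc3)cc21` is the next compound to be measured. Relative to compound 2 the change is fluoro in place of methoxy on an aromatic carbon. Within the data shown here, the one measured step that bears on this position on the ring is a 1.7-fold lower number from compound 1 to compound 2 (0.23 log units; within the scatter), which was within the scatter; no measured step covers fluoro at this place. Since putting methoxy onto the shared core moved the number by no more than the scatter, removing it again and setting fluoro there is expected to leave the number close to where compounds 1 and 2 already lie. For compound 3 the estimate in this assay is 4 h, with a range of 2 h to 8 h. The expected step is a 1.4-fold higher number from compound 2 to compound 3 (0.14 log units; within the scatter), not beyond the scatter.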

Compound 3, half-life: > 5 h
Compound 3: no number, only a limit (the forecaster's own chance of this, stated with the estimate: 5%); middle value at least 1.2-fold (0.09 log units) away from the limit.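

In this assay compound 3 gives > 5 h, which is a limit of the assay and not a number: the limit of > 5 h in this assay, at which 1 of the 3 values shown sits.

For 4-methoxyphenyl to 4-fluorophenyl the step reads an at least 1.7-fold higher number from compound 2 to compound 3 (0.23 log units; that floor lies within the scatter), and for fluoro in place of hydrogen at the same place it reads an at least 1.0-fold higher number from compound 1 to compound 3 (0.00 log units; that floor lies within the scatter). Neither floor passes the scatter, but unlike the earlier methoxy step, which was a complete reading, these two steps are open at the upper end, so this place on the ring now carries a change whose full size the read-out does not give.

Still open, as far as these compounds go, is whether compound 3 lies just past the limit or far past it, and so whether fluoro at this place separates from hydrogen and methoxy at all. Also open is how a group of another kind at this place, such as an amine or a carboxylic acid, would read in this assay, since the compounds shown carry only hydrogen, methoxy and fluoro there.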